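Chloro on the benzyl group: compound 2 to compound 4

The source may report more compounds than this note shows. Statements on the series, on what has been measured and on what is new or still open speak of the compounds shown alone.

Compound 2 `COc1ccc2cc([C@H](C)c3nnc(SCc4ccccc4)n3-c3ccc(Cl)cc3)ccc2c1` is the lower of the two plain numbers recorded in a functional assay on LNCaP cells (Homo sapiens) for cytotoxicity, read by MTT assay; a higher number here means a weaker inhibitor, a lower number a stronger inhibitor: compound 2 gives 50400 nM. Compound 1 `COc1ccc2cc([C@H](C)c3nnc(SCc4ccc(F)cc4)n3-c3ccc(F)cc3)ccc2c1` is the nearest measured neighbour, and in this assay compound 1 gives 104000 nM, a gap that lies beyond the scatter of the assay. Compound 3 `COc1ccc2cc([C@H](C)c3nnc(SCc4c(C)cc(C)cc4C)n3-c3cccc(Cl)c3)ccc2c1` carries no number in this assay; compound 3 shows <= 400000 nM, which is a limit of the assay rather than a measured value. Compound 3 thus sits at the limit of <= 400000 nM in this assay, at which 1 of the 3 values shown sits.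

Compound 4 `COc1ccc2cc([C@H](C)c3nnc(SCc4ccc(Cl)cc4)n3-c3ccc(Cl)cc3)ccc2c1` differs from compound 2 in one place: chloro in place of hydrogen on an aromatic carbon. Among the compounds with values here, no pair of measured compounds covers this change alone; compound 1 and compound 2 differ in more than one place, so their values say only that compound 1 gives the higher number. The step from compound 2 to compound 4 is expected to stay within the scatter, with no clear direction. The expected step is a 1.1-fold lower number from compound 2 to compound 4 (0.05 log units; within the scatter). Compound 4 is estimated at 45000 nM in this assay, with a range from 18000 nM to 120000 nM.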

Compound 4, half-maximal inhibitory concentration: 110000 nM
Compound 4: middle estimate off by 2.4-fold (0.39 log units), on the low side; the measured number falls inside the stated range.
By their numbers in this assay, from the lowest: compound 2; then compounds 1 and 4 (each within the scatter of the next).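

In this assay, within the data shown here, the change from benzyl to 4-chlorobenzyl gives the only single-change reading: a 2.2-fold higher number from compound 2 to compound 4 (0.34 log units; beyond the scatter). This aromatic carbon, para to a large group, therefore does not take chloro in place of hydrogen neutrally, although the modest step runs towards the weaker side. No measurement shown accounts for this step.

One step at one position cannot show whether the loss is specific to chloro, or whether a methoxy group, an amine or a carboxylic acid at this place would move the number the same way. It also leaves open whether the step holds when the 4-chlorophenyl group on the core is replaced by another aryl group.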